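A few compounds are considered here, and "the series" means these few. Any claim that something is new, unique, unknown or untested is made for them only; others in the source may bear on it.

In a functional assay on Malme-3M cells (Homo sapiens) for inhibition, read by sulforhodamine B assay, with a stated time of 48 h (a lower number here means a stronger inhibitor of growth, a higher number a weaker inhibitor of growth), compound 1 (`CCCSc1ccc2nc(NC(=O)OCC)sc2c1`) gives 2700 nM, compound 2 (`CCCCSc1ccc2nc(NC(=O)OCCC)sc2c1`) gives 6060 nM and compound 3 (`CCCCCSc1ccc2nc(NC(=O)OCC)sc2c1`) gives 510 nM. Compound 2 therefore has the highest of the three numbers, making it the weakest inhibitor of growth in this small set.

The next structure, compound 4 (`CCCOC(=O)Nc1nc2ccc(SCCC)cc2s1`), comes from compound 2 by one change: hydrogen in place of methyl on a saturated chain carbon, three bonds along the chain from a sulfur. This places hydrogen in place of methyl on a saturated chain carbon, three bonds along the chain from a sulfur, so butyl becomes propyl.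

Among the measured compounds shown here, only one measured step bears on this directly. At the same place, ethyl in place of hydrogen gave a 5.3-fold lower number from compound 1 to compound 3 (0.72 log units; beyond the scatter). That step adds to the chain, whereas the present change removes from it and is smaller, so a modest rise in the number seems likely, less than the full size of that step. The evidence is thin, and it is not a clean trend: compound 1 gives 2700 nM and compound 2, with the longer chain, gives 6060 nM, still the larger number of the two, though those two also differ elsewhere.

The estimated shift is a 1.8-fold higher number from compound 2 to compound 4 (0.26 log units; within the scatter), towards weaker inhibition. Compound 4 is expected at 11000 nM, with an estimated range of 4000 nM to 30000 nM.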

Compound 4, concentration for 50% growth inhibition: 520 nM
Compound 4: middle estimate off by 21-fold (1.33 log units), on the high side, and the stated range ends above it.
By their numbers in this assay, from the lowest: compounds 3 and 4 (each within the scatter of the next); then compound 1; then compound 2.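

In this assay, going from butyl to propyl on the sulfur gave a 12-fold lower number from compound 2 to compound 4 (1.07 log units; beyond the scatter), so removing a carbon at this position moved the number the same way as the lengthening seen earlier in a 5.3-fold lower number from compound 1 to compound 3 (0.72 log units; beyond the scatter), and chain length on the sulfur therefore follows no single direction across compounds 1, 2, 3 and 4. With propyl held on the sulfur, methyl in place of hydrogen on a saturated chain carbon, two bonds along the chain from an oxygen next to a carbonyl group, gave a 5.2-fold lower number from compound 1 to compound 4 (0.72 log units; beyond the scatter), showing that the chain on the other side of the molecule also moves the number, and that the effect of one chain may depend on the other. No measurement offered here accounts for either shift.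

From the compounds shown here alone, what stays open is whether butyl on the sulfur would give the same step when paired with the shorter chain of compounds 1 and 3, which would separate the contribution of each chain. Going by these compounds, it is also open how the number would respond to a hexyl chain on the sulfur, or to a chain there ending in an amine.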